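Benzyl replacement for the lactone in the thioether series

The compounds below may be only part of what the source reports. "The series", "measured", "known", "first", "only" and "open" are said of these compounds alone.

Measured so far:
compound 1 `CO[C@]1(C)C[C@H](O)C[C@@H](CSc2nc(-c3ccccc3)c(-c3ccccc3)[nH]2)O1`, 30 nM
compound 2 `CC1(C)CC(=O)OC(CSc2nc(-c3ccccc3)c(-c3ccccc3)[nH]2)C1`, 100 nM

In an assay on microsomes from liver for inhibition of sterol O-acyltransferase 1 (Rattus norvegicus) (a higher number here means a weaker inhibitor, a lower number a stronger inhibitor), compound 2 gives 100 nM, the highest of the two numbers; compound 1 gives 30 nM, a lower number beyond the scatter.

Compound 3 `c1ccc(CSc2nc(-c3ccccc3)c(-c3ccccc3)[nH]2)cc1` is not yet measured. It differs from compound 2 as follows: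
a group of 6 heavy atoms (6 carbon; one six-membered aromatic ring of carbon only) in place of a group of 9 heavy atoms (7 carbon, 2 oxygen; one six-membered non-aromatic ring with 1 hetero atom), on a saturated chain carbon bound to a sulfur

Within the data shown here, no step between measured compounds bears on this change, so the size of the step is open. A modest rise in the number is expected, a 1.8-fold higher number from compound 2 to compound 3 (0.26 log units; within the scatter), close to the scatter rather than well beyond it. For compound 3 the estimate is 180 nM, between 50 nM and 700 nM.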

Compound 3, half-maximal inhibitory concentration: 290 nM
Compound 3: middle estimate off by 1.6-fold (0.21 log units), on the low side, within the range that was stated.
By their numbers in this assay, from the lowest: compound 1; then compound 2; then compound 3.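

In this assay, phenyl in place of the group of 9 heavy atoms, on a saturated chain carbon bound to a sulfur, gives a 2.9-fold higher number from compound 2 to compound 3 (0.46 log units; beyond the scatter) as a modest loss. Activity therefore survives without the non-aromatic ring and its hydrogen-bond acceptors, though compound 2 keeps a clear edge over compound 3. No supporting data explain this step.

Which part of the group of 9 heavy atoms accounts for that edge remains open. Also open, on these data alone, is how a longer chain bearing phenyl, an amine or a carboxylic acid would fare here.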